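Two ribosides, one limit, one fluorinated analog to come

The compounds below may be only part of what the source reports. "The series", "measured", "known", "first", "only" and "open" are said of these compounds alone.

Compound 1: `OC[C@H]1O[C@@H](n2cnc3c(NCc4ccccc4F)ncnc32)[C@H](O)[C@@H]1O` — "not determined" (no result reported)
Compound 2: `COc1ccccc1CNc1ncnc2c1ncn2[C@@H]1O[C@H](CO)[C@@H](O)[C@H]1O` — > 166000 nM
Compound 3: `COc1cccc(CNc2ncnc3c2ncn3[C@@H]2O[C@H](CO)[C@@H](O)[C@H]2O)c1OC` — "not determined" (no result reported)

Three compounds share one core and differ only in the substituted phenyl on the saturated chain carbon bound to a nitrogen on an aromatic ring. In a functional assay on G-361 cells (Homo sapiens) for antiproliferative activity, with a stated time of 72 h (a higher number here means a weaker inhibitor, a lower number a stronger inhibitor), compound 2 reaches only a limit, > 166000 nM, and no number. Compound 1 has no result in this assay, "not determined" (no result reported). Compound 3 likewise stands without a number, "not determined" (no result reported). Among the compounds with values here, the place of compound 3 can therefore only be framed by the one limit, (the limit of > 166000 nM in this assay, at which 1 of the 3 values shown sits), and by the one entry without a number; no step between measured compounds exists.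

Compound 4, `OC[C@H]1O[C@@H](n2cnc3c(NCc4c(F)ccc(F)c4F)ncnc32)[C@H](O)[C@@H]1O`, carries 2,3,6-trifluorophenyl in place of 2,3-dimethoxyphenyl on a saturated chain carbon bound to a nitrogen on an aromatic ring. Within the data shown here, with no measured step to draw on, the size and direction of any shift cannot be told beyond the scatter. Compound 4 is expected in this assay to give about 100000 nM, within a range from 20000 nM to 200000 nM.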

Compound 4, half-maximal inhibitory concentration: > 166000 nM
Compound 4 was reported as a limit (the forecaster's own chance of this, stated with the estimate: 55%); middle value at least 1.6-fold (0.22 log units) away from the limit.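

In this assay compound 4 gives > 166000 nM as a limit and not a number. No step can be read between compound 2 and compound 4, since both stand at a limit: the limit of > 166000 nM in this assay, at which 2 of the 4 values shown sit. The compounds shown leave open whether any substituted phenyl on the shared core gives a measurable value.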